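The source may report more compounds than this note shows. Statements on the series, on what has been measured and on what is new or still open speak of the compounds shown alone.

In a functional assay on MCF7 cells (Homo sapiens) for antiproliferative activity, read by MTT assay, with a stated time of 48 h (on this read-out higher numbers stand for weaker inhibition and lower numbers for stronger inhibition), compound 1 `Fc1ccc(-c2nn(-c3ccccc3)cc2-c2nc3cc(Cl)ccc3[nH]2)cc1` gives 2230 nM, compound 2 `Fc1ccc(-c2nn(-c3ccccc3)cc2-c2nc3cc(Cl)c(Cl)cc3[nH]2)cc1` gives 6930 nM and compound 3 `FC(F)(F)c1ccc2[nH]c(-c3cn(-c4ccccc4)nc3-c3ccc(Cl)cc3)nc2c1` gives 4210 nM. Compound 2 thus lies within the scatter of compound 3 and beyond the scatter from compound 1. Compound 4 `Clc1ccc(-c2nn(-c3ccccc3)cc2-c2nc3cc(Cl)c(Cl)cc3[nH]2)cc1` differs from compound 2 by chloro in place of fluoro on an aromatic carbon. Among the measured compounds shown here, no measured step makes this change. For the measured compounds named here, the one measured step, a 3.1-fold higher number from compound 1 to compound 2 (0.49 log units; beyond the scatter), is modest and is a different change, so it bears only loosely. Compound 3, which carries the 4-chlorophenyl group, stays within the scatter of compound 2. No shift beyond the scatter is therefore expected in this assay. The expected step is a 1.2-fold lower number from compound 2 to compound 4 (0.06 log units; within the scatter). Compound 4 is estimated at 6000 nM, with an expected range of 2800 nM to 13000 nM.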

Compound 4, half-maximal inhibitory concentration: 48300 nM
Compound 4: the middle estimate sits 8.1-fold (0.91 log units) below what was measured; the measured number lies above the stated range.
By their numbers in this assay, from the lowest: compounds 1, 3 and 2 (each within the scatter of the next, the first and the last beyond it); then compound 4.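

In this assay, replacing 4-fluorophenyl with 4-chlorophenyl gives a 7.0-fold higher number from compound 2 to compound 4 (0.84 log units; beyond the scatter), so a single halogen exchange at this position, para to a large group, moves the number beyond the scatter. Among the compounds shown here, the earlier compounds offered no matched pair at this position, so this is the first direct reading of its sensitivity. No measurement shown here accounts for the shift. On these data alone, it remains open how a methyl or methoxy group, or hydrogen, would read at this position. As far as these compounds go, whether the same exchange gives a similar step with the substitution pattern of compound 1 also remains open.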